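Benzothiazole to benzimidazole on the sulfur: stability outlook

A few compounds are considered here, and "the series" means these few. Any claim that something is new, unique, unknown or untested is made for them only; others in the source may bear on it.

In an ADME assay on microsomes from liver (Homo sapiens) for metabolic stability, read by LC-MS, with a stated time of 15 min (a higher number here means that more of the compound is left, a lower number that less of the compound is left), compound 1 `O=C(N/N=C/c1ccc(CSc2nc3ccccc3o2)cc1)c1ccncc1` gives 90.1%. Going by the values given here, compound 2 `O=C(N/N=C/c1ccc(CSc2nc3ccccc3s2)cc1)c1ccncc1` gives 76.3%, the lower of the two numbers measured so far, and that pair shows a number 13.8 percentage points lower from compound 1 to compound 2 (beyond the scatter). Compound 3 `O=C(N/N=C/c1ccc(CSc2nc3ccccc3[nH]2)cc1)c1ccncc1` differs from compound 2 by 1H-benzimidazol-2-yl in place of 1,3-benzothiazol-2-yl on a sulfur. Among the compounds with values here, no measured step makes this exact exchange; the one step seen also swapped the ring on that sulfur and moved the read-out modestly. A modest shift, with its direction uncertain, is therefore expected, a number 1.7 percentage points higher from compound 2 to compound 3 (within the scatter). Compound 3 is estimated at 78%, in a range from 58% to 95%.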

Compound 3, percent of the compound remaining: 76.5%
Estimate against measurement, compound 3: 1.5 percentage points above, within the range that was stated.
By their numbers in this assay, from the lowest: compounds 2 and 3 (each within the scatter of the next); then compound 1.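

On the sulfur, the 1H-benzimidazol-2-yl, which carries a hydrogen-bond donor, can take the place of the 1,3-benzothiazol-2-yl with no change beyond the scatter in this assay: a number 0.2 percentage points higher from compound 2 to compound 3 (within the scatter). Set against the 1,3-benzoxazol-2-yl, however, the same group gives a number 13.6 percentage points lower from compound 1 to compound 3 (beyond the scatter), so compound 1 stands clear of both other compounds, which cannot be told apart. Nothing available here explains this pattern. Left open is how an amine or a longer chain on that sulfur, in place of these groups, would read in this assay.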